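A Nitrogen Enters the Chlorinated Ring

A few compounds are considered here, and "the series" means these few. Any claim that something is new, unique, unknown or untested is made for them only; others in the source may bear on it.

In a functional assay on HeLa cells (Homo sapiens) for inhibition, read by MTT assay, with a stated time of 72 h (a higher number here means a weaker inhibitor, a lower number a stronger inhibitor), compound 3 `Cc1noc(C)c1-c1cnc(N)c(Oc2ccc(C(=O)Nc3cccc(Cl)c3)cc2)n1` gives 1340 nM and holds the lowest of the three numbers. Compound 1 `CCCNC(=O)c1ccc(Oc2nc(-c3c(C)noc3C)cnc2N)cc1` gives 32100 nM and compound 2 `Cc1noc(C)c1-c1cnc(N)c(Oc2ccc(C(=O)Nc3ccccc3Cl)cc2)n1` gives 81300 nM. Compound 4 `Cc1noc(C)c1-c1cnc(N)c(Oc2ccc(C(=O)Nc3ncccc3Cl)cc2)n1` carries 3-chloropyridin-2-yl in place of 3-chlorophenyl on an amide-type nitrogen. Among the compounds with values here, no measured step makes this exact swap, but changes at that nitrogen have mattered: two steps were large (a 24-fold lower number from compound 1 to compound 3 (1.38 log units; beyond the scatter) and a 61-fold lower number from compound 2 to compound 3 (1.78 log units; beyond the scatter)) and one modest (a 2.5-fold higher number from compound 1 to compound 2 (0.40 log units; beyond the scatter)). The entering group resembles the 2-chlorophenyl of compound 2 (81300 nM) more than the 3-chlorophenyl of compound 3, so a large move to a higher number is expected in this assay. The expected change is a 15-fold higher number from compound 3 to compound 4 (1.17 log units; beyond the scatter) (an estimate). Compound 4 is estimated at 20000 nM (expected range 4000 nM to 90000 nM).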

Compound 4, half-maximal inhibitory concentration: 31900 nM
Compound 4: middle estimate off by 1.6-fold (0.20 log units), on the low side; the range from low to high includes it.
By their numbers in this assay, from the lowest: compound 3; then compounds 4 and 1 (each within the scatter of the next); then compound 2.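

Placing a nitrogen in the chlorinated ring cancels the advantage of the 3-chlorophenyl group in this assay (a 24-fold higher number from compound 3 to compound 4 (1.38 log units; beyond the scatter)). The 3-chloropyridin-2-yl group still gives a lower number than 2-chlorophenyl (a 2.5-fold lower number from compound 2 to compound 4 (0.41 log units; beyond the scatter)), yet it cannot be told apart from propyl (a 1.0-fold lower number from compound 1 to compound 4 (0.00 log units; within the scatter)). No measurement here explains these shifts. On these data alone, whether the loss comes from the ring nitrogen alone, or needs the chlorine too, remains open. Also open, as far as these compounds go, is how an unsubstituted phenyl or pyridin-2-yl group, or a longer chain, would read on the amide-type nitrogen.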